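This account rests on a few compounds, and the source may have more. Where it says the series, first, only, none or still open, it means among the compounds named here.

Measured so far:
compound 1, `CC(C)N(Cc1cccc(OCCCCCC(=O)O)c1)C(=O)c1ccccc1` — in an ADME assay on BJ cells (Homo sapiens) for cytotoxicity, read by CellTiter-Glo and resazurin assay, with a stated time of 72 h (on this read-out higher numbers stand for an effect only at larger amounts of compound and lower numbers for an effect already at smaller amounts), compound 1 gives > 26000 nM, which is a limit of the assay.
compound 2, `CC(C)N(Cc1cccc(OCCCCCC(=O)O)c1)C(=O)c1ccc(-c2c[nH]c3ccccc23)cc1` — in this assay compound 2 gives > 26000 nM, likewise a limit of the assay.
compound 3, `CCOC(=O)CCCCCOc1cccc(CN(C(=O)c2ccccc2)C(C)C)c1` — in this assay compound 3 gives > 26000 nM, again a limit of the assay.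

Compound 3 therefore stands at the same limit as the other two measured compounds; no number is known for any of them, and nothing orders the three against one another (the limit of > 26000 nM in this assay, at which 3 of the 3 values shown sit).

Compound 4, `CCOC(=O)CCCCCOc1cccc(CN(C(=O)c2ccc(-c3cc(OC)cc(OC)c3)cc2)C(C)C)c1`, is not yet measured. It differs from compound 3 in one place: 3,5-dimethoxyphenyl in place of hydrogen on an aromatic carbon.

Among the compounds with values here, two measured steps touch on this kind of change, but neither is readable: a step that the two limits leave unreadable from compound 1 to compound 2 and a step that the two limits leave unreadable from compound 1 to compound 3. Going by these compounds, both begin and end at the limit, so their size and direction stay unknown. Within the data shown here, the data thus give no measured basis for a step of any particular size; the only observation is that every compound tested so far shows no effect up to the limit in this assay.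

The step is expected to be a step that the limit leaves unreadable from compound 3 to compound 4. Compound 4 is estimated at 40000 nM, within a range of 15000 nM to 150000 nM. Most likely the assay again reports only a limit for compound 4.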

Compound 4, half-maximal effective concentration: > 26000 nM
Compound 4: only a limit was reported; the forecaster's own chance of this, stated with the estimate: 80%; the middle value is on the limit's open side.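

Compound 3 and compound 4 both sit at a limit of the assay, and no step between them can be read: the limit of > 26000 nM in this assay, at which 4 of the 4 values shown sit.

The compounds shown leave open how the four compare with one another in this assay, and at what concentration, if any, any of them produces an effect on these cells.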